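A Second Chloro on Compound 3

This account rests on a few compounds, and the source may have more. Where it says the series, first, only, none or still open, it means among the compounds named here.

In a functional assay on the whole organism for inhibition, with Rattus norvegicus as the target, with a stated time of 5 min (on this read-out higher numbers stand for an effect only at larger amounts of compound and lower numbers for an effect already at smaller amounts), compound 1 `O=C(O)CCCOc1cccc(/C=C/c2ccc3cc(Cl)ccc3n2)c1` gives 1.5 mg/kg, and compound 2 `CCOC(=O)CCCOc1cccc(/C=C/c2ccc3ccccc3n2)c1` gives 1.5 mg/kg. Compound 3 `O=C(O)CCCOc1cccc(/C=C/c2ccc3ccc(Cl)cc3n2)c1` gives 0.5 mg/kg, the lowest of the three numbers and beyond the scatter from both others. Compound 4 `O=C(O)CCCOc1cccc(/C=C/c2ccc3cc(Cl)c(Cl)cc3n2)c1` is compound 3 with chloro in place of hydrogen on an aromatic carbon, ortho to a chloro group (chloro in place of hydrogen on an aromatic carbon). For the measured compounds named here, no two measured compounds differ in just one place, so this expectation is loose. Compound 4 carries the chloro groups of both compound 3 and compound 1, and compound 1 gives 1.5 mg/kg. The expected step of a 1.6-fold higher number from compound 3 to compound 4 (0.20 log units; within the scatter) is therefore a modest rise in the number, within the scatter. Compound 4 is estimated at 0.8 mg/kg, with an expected range of 0.25 mg/kg to 2.5 mg/kg.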

Compound 4, dose for half-maximal effect: 0.5 mg/kg
For compound 4 the middle estimate is 1.6-fold (0.20 log units) above the measured one, and the stated range covers the measured number.
By their numbers in this assay, from the lowest: compounds 3 and 4 (each within the scatter of the next); then compounds 1 and 2 (each within the scatter of the next).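

In this assay the second chloro group, ortho to the first, gives no change at the digits printed from compound 3 to compound 4 (within the scatter) and so costs nothing measurable at this position. The other step, again chloro in place of hydrogen on an aromatic carbon, gives a 3.0-fold lower number from compound 1 to compound 4 (0.48 log units; beyond the scatter) and brings compound 4 level with compound 3, so with both chloro groups present the number follows compound 3 and not compound 1. No measured evidence here accounts for either step. Still open, from the compounds shown here alone, is whether a fluoro, a methoxy or an amine at this position would leave the number unchanged as well.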